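The source may report more compounds than this note shows. Statements on the series, on what has been measured and on what is new or still open speak of the compounds shown alone.

Compound 2 `O=C1C(=O)N(CCCCn2cc(COc3cc(=O)oc4ccccc34)nn2)c2ccc(Cl)cc21`: 60%
Compound 1 `O=C1C(=O)N(CCCCCn2cc(COc3cc(=O)oc4ccccc34)nn2)c2ccc(Br)cc21`: 39%

Of the compounds shown here, two have been measured in a functional assay on COLO 205 cells (Homo sapiens) for inhibition, read by sulforhodamine B assay, with a stated time of 48 h, tested at 50 uM; a lower number here means less inhibition of growth, a higher number more inhibition of growth at the concentration tested. Compound 2 gives 60%, the highest of the two numbers. Its nearest neighbour, compound 1, gives 39%, a number lower by a margin beyond the scatter. Among the measured compounds shown here, the two differ in more than one place, so no single-change step connects them, and only their two values can be set side by side.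

Compound 3 `COc1ccc2c(c1)C(=O)C(=O)N2CCCCn1cc(COc2cc(=O)oc3ccccc23)nn1` has not yet been measured. Its difference from compound 2 is this: methoxy in place of chloro on an aromatic carbon. For the measured compounds named here, no measured pair shows what this exchange does in this assay, so any expectation rests on compound 2 alone and on the spread seen between compound 2 and compound 1. The step of a number 12 percentage points lower from compound 2 to compound 3 (beyond the scatter) is expected to be a modest drop, close to the edge of the scatter rather than clearly beyond it. Compound 3 is therefore expected to give 48%, with a range from 25% to 70%.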

Compound 3, percent growth inhibition at one concentration: 41%
The estimate for compound 3 lay 7 percentage points above the measured number, and the stated range covers the measured number.
By their numbers in this assay, from the lowest: compounds 1 and 3 (each within the scatter of the next); then compound 2.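

In this assay, the exchange of chloro for methoxy on an aromatic carbon gives the only single-change step among these compounds, a number 19 percentage points lower from compound 2 to compound 3 (beyond the scatter). It shows that this place on the shared core is not indifferent to what it carries: with the rest of compound 2 unchanged, replacing one chlorine atom with a group of one carbon and one oxygen, which brings in one hydrogen-bond acceptor, moves growth inhibition at the concentration tested beyond the scatter. Nothing at hand explains this drop, so the step records only its direction and size.

Compound 1 carries bromo at this place but also differs in its chain, so its value cannot be read as the effect of bromo alone. Still open, as far as these compounds go, is how other groups at this place, such as fluoro, an amine, a nitrile or a carboxylic acid, would fall relative to chloro and methoxy, and whether the same exchange would give a similar step on a compound with a longer chain.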